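Working Notes on the Step from Compound 2 to Compound 3

The compounds below may be only part of what the source reports. "The series", "measured", "known", "first", "only" and "open" are said of these compounds alone.

compound 1 `CCN(Cc1ccccc1)C(=O)C1CCN(S(=O)(=O)c2ccc(OC)cc2)CC1`: 84%
compound 2 `CCN(C(=O)C1CCN(S(=O)(=O)c2ccc(OC)cc2)CC1)[C@@H](C)c1ccccc1`: "not determined" (no result reported)

In a functional assay on CHO cells for positive allosteric modulation of muscarinic acetylcholine receptor M5 (Homo sapiens), read by calcium flux (on this read-out lower numbers stand for smaller maximal responses and higher numbers for larger maximal responses), compound 1 gives 84%. For compound 2 this assay reports "not determined" (no result reported), so compound 2 stands without a number and the only measured point in the series is compound 1. Compound 3 `CCN(C(=O)C1CCN(S(=O)(=O)c2ccc(OC)cc2)CC1)[C@H](C)c1ccccc1` is not yet measured. The change from compound 2 to compound 3 is the two compounds have the same atoms and bonds and differ only in configuration as drawn: 1 of 1 stereo elements differ; a stereocentre at a saturated chain carbon is drawn S in compound 2 and R in compound 3. Within the data shown here, no step between two measured compounds exists, so there is nothing from which the size of this step can be read. For a change in configuration alone the step in this assay may lie anywhere, from none beyond the scatter to a large shift in either direction. The expectation rests only on compound 1, whose 84% is the single number shown. The maximal response of compound 3 is therefore estimated near 70%, with an expected range from 30% to 110%.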

Compound 3, largest response reached (reported as percent of maximum), in percent of the reference or control that the assay uses: 90%
Beside the measured number, compound 3's estimate is 20 percentage points below it, within the range that was stated.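

In this assay, methyl in place of hydrogen on a saturated chain carbon bound to an amide-type nitrogen and an aromatic carbon gives a number 6 percentage points higher from compound 1 to compound 3 (within the scatter). Among these compounds, this is the first readable step, and it shows that this carbon can carry a methyl, drawn R, with a maximal response that cannot be told apart from that of the unbranched compound 1. The S form remains without a number, and what separates it from the R form is stated by the structures alone: the fact that compounds 2 and 3 differ only in the configuration as drawn

On these data alone, compound 2 has no value, so the step to compound 3 cannot be read and the role of configuration at this carbon stays open. The compounds shown also leave open whether a longer chain such as propyl, or a hydroxymethyl, at this carbon would keep the maximal response.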